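The source may report more compounds than this note shows. Statements on the series, on what has been measured and on what is new or still open speak of the compounds shown alone.

In an ADME assay on MT4 cells (Homo sapiens) for cytotoxicity, read by MTT assay, with a stated time of 5 days (on this read-out lower numbers stand for higher toxicity in this test and higher numbers for lower toxicity in this test), compound 1 (`Cc1cc(/C=C/C#N)cc(C)c1Oc1nc(Nc2ccc(CN3CCN(S(C)(=O)=O)CC3)cc2)nc2ccsc12`) gives 20700 nM and compound 2 (`Cc1cc(/C=C/C#N)cc(C)c1Oc1nc(Nc2ccc(CN3CCN(S(C)(=O)=O)CC3)cc2)nc2sccc12`) gives 131000 nM. Compound 2 therefore holds the higher of the two numbers, and the gap to compound 1 lies beyond the usual scatter. On this read-out, compound 2 is the less toxic of the pair.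

Compound 3 (`Cc1cc(/C=C/C#N)cc(C)c1Oc1nc(Nc2ccc(N3CCCC(N)C3)cc2)nc2sccc12`) departs from compound 2 at a single place. On an aromatic carbon of a six-membered aromatic ring of carbon only, para to a large group, 3-aminopiperidin-1-yl stands in place of (4-(methylsulfonyl)piperazin-1-yl)methyl: 3-aminopiperidin-1-yl in place of (4-(methylsulfonyl)piperazin-1-yl)methyl on an aromatic carbon.

Among the compounds with values here, no measured pair shows this exchange, so the expectation rests on little. Compound 2 sits at 131000 nM, high on the scale seen so far, and compound 1, with 20700 nM, shows that a much lower number is possible. A move toward lower numbers in this assay is therefore expected, beyond the scatter, and the estimated change is a 7.3-fold lower number from compound 2 to compound 3 (0.86 log units; beyond the scatter). For compound 3 the expected value is 18000 nM, with an estimated range from 5000 nM to 65000 nM.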

Compound 3, half-maximal cytotoxic concentration: 4610 nM
Compound 3: middle estimate off by 3.9-fold (0.59 log units), on the high side, outside the stated range (below it).
By their numbers in this assay, from the lowest: compound 3; then compound 1; then compound 2.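

The exchange of (4-(methylsulfonyl)piperazin-1-yl)methyl for 3-aminopiperidin-1-yl gives, in this assay, a 28-fold lower number from compound 2 to compound 3 (1.45 log units; beyond the scatter), which shows that this position on the six-membered aromatic ring of carbon only can shift the read-out strongly toward higher toxicity in this test, something the earlier pair could not show, as its two members differ only in the core. This single step changes several things at once: the entering group has fewer heavy atoms, brings a hydrogen-bond donor that the leaving group lacks, has one hetero atom in its ring instead of two, and has no double bonds outside aromatic rings, so no one of these differences can be singled out. No measurement offered here accounts for the size of this step.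

On these data alone, it remains open which part of the exchange carries the step, and a hydroxyl group or an acetamide in place of the amine on the piperidine ring, or a piperazine ring without the methylsulfonyl group, would help to separate these differences. As far as these compounds go, it also remains open whether 3-aminopiperidin-1-yl would bring a similar step on the core of compound 1.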